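The source may report more compounds than this note shows. Statements on the series, on what has been measured and on what is new or still open speak of the compounds shown alone.

Working notes on the series. Among the measured compounds shown here, compound 3 `COc1cc(-c2nn(-c3cccc(NC(=O)Nc4ccc(Cl)c(C(F)(F)F)c4)c3)cc2-c2ccncc2)ccc1Cl` is the member for which a functional assay on SK-MEL-28 cells (Homo sapiens) for inhibition, read by sulforhodamine B assay, with a stated time of 48 h (a higher number here means that more compound is tolerated, a lower number that less compound is tolerated), returns a number: compound 3 gives 19100 nM, the only number among the three measured entries. Compound 1 `O=C(Nc1cccc(-n2cc(-c3ccncc3)c(-c3ccc(Cl)c(O)c3)n2)c1)Nc1cccc(C(F)(F)F)c1` sits at a limit of this assay, giving > 32500 nM. Compound 2 `O=C(Nc1cccc(-n2cc(-c3ccncc3)c(-c3ccc(Cl)c(O)c3)n2)c1)Nc1ccc(Cl)c(Cl)c1` also sits at a limit, giving > 32500 nM. The step from compound 1 to compound 2 is a step that the two limits leave unreadable from compound 1 to compound 2, since the limit of > 32500 nM in this assay, at which 2 of the 3 values shown sit, caps both ends of it.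

Compound 4 `O=C(Nc1cccc(-n2cc(-c3ccncc3)c(-c3ccc(Cl)c(O)c3)n2)c1)Nc1ccc(Cl)c(C(F)(F)F)c1` is not yet measured. Against compound 3 it carries hydrogen in place of methyl on an oxygen on an aromatic ring. For the measured compounds named here, no measured step touches this oxygen; the one recorded step concerns the aryl on the urea and is itself unreadable. What can be said is that compound 1 and compound 2, both bearing the hydroxy that compound 4 bears, each sit at the limit, while compound 3 with its methoxy gives a number not far beneath that limit. On that basis compound 4 is expected to move toward the limit, a step of a 1.6-fold higher number from compound 3 to compound 4 (0.20 log units; within the scatter) in this assay, with a real chance that only a limit is reported. Compound 4 is accordingly estimated at 30000 nM, within a range of 12000 nM to 70000 nM.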

Compound 4, concentration lethal to 50% of the cells: 12400 nM
For compound 4 the middle estimate is 2.4-fold (0.38 log units) above the measured one; low and high end bracket the measured number.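

Methoxy and hydroxy on this aromatic ring are not told apart in this assay by the one matched pair available, which shows a 1.5-fold lower number from compound 3 to compound 4 (0.19 log units; within the scatter) and nothing more. With the hydroxy held, the aryl on the urea does register: trifluoromethyl in place of chloro on an aromatic carbon gives an at least 2.6-fold lower number from compound 2 to compound 4 (0.41 log units; beyond the scatter) and chloro in place of hydrogen on an aromatic carbon gives an at least 2.6-fold lower number from compound 1 to compound 4 (0.41 log units; beyond the scatter) so the hydroxy alone does not fix a compound at the limit. Both sizes are minimum sizes only, because each step starts from a limit: the limit of > 32500 nM in this assay, at which 2 of the 4 values shown sit.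

Going by these compounds, how an amine or a longer ether chain would read in place of the hydroxy stays open. Also open, on these data alone, is whether methoxy and hydroxy stay indistinguishable with a carboxylic acid on the aryl of the urea.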